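The compounds below may be only part of what the source reports. "The series", "measured", "known", "first", "only" and "open" are said of these compounds alone.

Compound 1 `Cc1nn(C)c(Oc2ccc(F)cc2)c1/C=N\OCc1c(Cl)c(-c2ccc(F)cc2)nn1C` gives 80% in a functional assay on SMMC-7721 cells (Homo sapiens) for inhibition, read by MTT assay, with a stated time of 72 h, tested at 25 uM; a higher number here means more inhibition at the concentration tested (going by the name of the read-out), a lower number less inhibition; compound 2 `Cc1nn(C)c(Oc2ccc(Cl)cc2)c1/C=N\OCc1c(Cl)c(-c2ccc(F)cc2)nn1C` gives 80% and compound 3 `Cc1nn(C)c(Oc2ccc(OC(F)(F)F)cc2)c1/C=N\OCc1c(Cl)c(-c2ccc(F)cc2)nn1C` gives 80%, so compound 1 stands level with both at the digits shown. The two measured steps that alter this aryl ether, no change at the digits printed from compound 1 to compound 2 (within the scatter) and no change at the digits printed from compound 1 to compound 3 (within the scatter), show no change beyond the scatter; the same holds for no change at the digits printed from compound 2 to compound 3 (within the scatter). Among the measured compounds shown here, compound 4 `Cc1nn(C)c(Oc2ccc(F)cc2)c1/C=N\OCc1c(Cl)c(-c2ccc(Cl)cc2)nn1C` carries the change (chloro in place of fluoro on an aromatic carbon), on the other aryl ring than the measured steps, so no step bears on it directly. The measured exchange of the same pair of groups on the ether ring, no change at the digits printed from compound 1 to compound 2 (within the scatter), is taken as the nearest guide, so compound 4 is expected to show a number 2 percentage points lower from compound 1 to compound 4 (within the scatter), with the estimate 78% in a range of 62% to 90%.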

Compound 4, a percentage reported as inhibition, at one concentration (the size of the read-out at that concentration, not a potency): 80%
Estimate against measurement, compound 4: 2 percentage points below; low and high end bracket the measured number.
By their numbers in this assay, from the lowest: compounds 1, 2, 3 and 4 (each within the scatter of the next).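

In this assay, among the compounds shown here, the change from 4-fluorophenyl to 4-chlorophenyl gives no change at the digits printed from compound 1 to compound 4 (within the scatter), the first reading at this position on the second aryl ring. With chloro in place of fluoro the number is therefore level here as well as on the ether ring, at least at this single test concentration. No supporting measurement accounts for this flat result.

As far as these compounds go, only fluoro and chloro appear at this position, so an amine, a carboxylic acid or a longer chain there remains open. With all four compounds level, how far this position can respond remains unsettled.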